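A few compounds are considered here, and "the series" means these few. Any claim that something is new, unique, unknown or untested is made for them only; others in the source may bear on it.

Measured compounds in a functional assay on A549 cells (Homo sapiens) for antiproliferative activity, read by MTT assay, with a stated time of 72 h; on this read-out lower numbers stand for stronger inhibition and higher numbers for weaker inhibition:
compound 1 `N=C(NS(=O)(=O)c1ccc(C(F)(F)F)cc1)N1CCN(c2cc3c(cc2F)c(=O)c(C(=O)O)cn3C2CC2)CC1` — 71 nM
compound 2 `CCn1cc(C(=O)O)c(=O)c2cc(F)c(N3CCN(C(=N)NS(=O)(=O)c4ccc(C(F)(F)F)cc4)CC3)cc21` — 71 nM
compound 3 `N=C(NS(=O)(=O)c1ccccc1C(F)(F)F)N1CCN(c2cc3c(cc2F)c(=O)c(C(=O)O)cn3C2CC2)CC1` — 71 nM

Compound 2 stands level with compounds 1 and 3 on these numbers; the steps of no change at the digits printed from compound 1 to compound 2 (within the scatter) and no change at the digits printed from compound 1 to compound 3 (within the scatter) both stay within the scatter. Compound 4 `CCn1cc(C(=O)O)c(=O)c2cc(F)c(N3CCN(C(=N)NS(=O)(=O)c4ccc(Cl)cc4)CC3)cc21` is not yet measured. Compound 4 differs from compound 2 by chloro in place of trifluoromethyl on an aromatic carbon, so that the phenyl on the sulfonyl sulfur reads 4-chlorophenyl instead of 4-(trifluoromethyl)phenyl. Going by the values given here, only the step from compound 1 to compound 3, which moves the trifluoromethyl about that ring without effect, touches this part of the molecule, and nothing measured exchanges the group itself. No step beyond the scatter is therefore expected; the estimated step is no change at the digits printed from compound 2 to compound 4 (within the scatter). For compound 4 the expected value in this assay is 71 nM, between 35 nM and 145 nM.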

Compound 4, half-maximal inhibitory concentration: 71 nM
Estimate against measurement, compound 4: no gap at the digits printed; the measured number falls inside the stated range.
By their numbers in this assay, from the lowest: compounds 1, 2, 3 and 4 (each within the scatter of the next).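

In this assay, going by these compounds alone, exchanging the group itself, chloro in place of trifluoromethyl on an aromatic carbon para to a large group, gives no change at the digits printed from compound 2 to compound 4 (within the scatter); the earlier compounds had only moved the trifluoromethyl about that ring. On these numbers, the two groups are interchangeable at this place, at least with ethyl on the aromatic nitrogen. No measurement is available that would explain this.

On these data alone, whether an amine or a methoxy group at this place would leave the number equally unmoved stays open. So does whether chloro behaves the same way with cyclopropyl on the aromatic nitrogen.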